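A shorter chain ending in a bare piperazine

The compounds below may be only part of what the source reports. "The series", "measured", "known", "first", "only" and "open" are said of these compounds alone.

In a functional assay on A549 cells (Homo sapiens) for cytotoxicity, read by MTT assay, with a stated time of 48 h (a higher number here means a weaker inhibitor, a lower number a stronger inhibitor), compound 1 (`COc1c(OCCCCN2CCCC2)cc(O)c2c(=O)cc(-c3ccccc3)oc12`) gives 1530 nM and compound 2 (`CCN(CC)CCCCOc1cc(O)c2c(=O)cc(-c3ccccc3)oc2c1OC`) gives 1000 nM while compound 3 (`COc1c(OCCCCN2CCN(C)CC2)cc(O)c2c(=O)cc(-c3ccccc3)oc12`) gives 1500 nM and so stands level with both. Compound 4 (`COc1c(OCCCN2CCNCC2)cc(O)c2c(=O)cc(-c3ccccc3)oc12`) departs from compound 3 (piperazin-1-yl in place of (4-methylpiperazin-1-yl)methyl on a saturated chain carbon, three bonds along the chain from an oxygen on an aromatic ring) on a saturated chain carbon, three bonds along the chain from an oxygen on an aromatic ring. The nearest measured steps swap only the amine: a 1.0-fold lower number from compound 1 to compound 3 (0.01 log units; within the scatter) and a 1.5-fold higher number from compound 2 to compound 3 (0.18 log units; within the scatter) are both within the scatter. Going by the values given here, no measured step shortens the chain or removes the methyl, so this evidence is indirect. Expected is no change at the digits printed from compound 3 to compound 4 (within the scatter) and no shift beyond the scatter. The estimated value for compound 4 is 1500 nM (range 600 nM to 3500 nM).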

Compound 4, half-maximal inhibitory concentration: 10100 nM
For compound 4 the middle estimate is 6.7-fold (0.83 log units) below the measured one; the whole stated range lies below it.
By their numbers in this assay, from the lowest: compounds 2, 3 and 1 (each within the scatter of the next); then compound 4.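

In this assay swapping the amine on the longer chain moved nothing beyond the scatter, yet the shorter chain ending in piperazin-1-yl gives a 6.7-fold higher number from compound 3 to compound 4 (0.83 log units; beyond the scatter) together with a 10-fold higher number from compound 2 to compound 4 (1.00 log units; beyond the scatter) and a 6.6-fold higher number from compound 1 to compound 4 (0.82 log units; beyond the scatter) as well. So this position does respond to change, and all three steps run towards a weaker inhibitor. Nothing measured here offers an explanation for this loss.

Chain length and the ring methyl change together in compound 4, so the compounds shown cannot separate them. A 4-methylpiperazin-1-yl on the shorter chain, or a bare piperazin-1-yl on the longer one, would tell the two apart.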